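Acetyl to dimethylcarbamoyl in a chemokine receptor series

The compounds below may be only part of what the source reports. "The series", "measured", "known", "first", "only" and "open" are said of these compounds alone.

Among the compounds with values here, in an assay on L1.2 cells for binding affinity to C-C chemokine receptor type 8 (Homo sapiens) (a lower number here means a stronger inhibitor, a higher number a weaker inhibitor), compound 3 `CC(=O)N1CCC(NS(=O)(=O)c2ccc(NC(=O)c3ccccc3C)c3ccccc23)CC1` gives 6.7 nM, the higher of the two numbers measured so far, and compound 2 `CCOC(=O)N1CCC(NS(=O)(=O)c2ccc(C(=O)Nc3ccccc3C)c3ccccc23)CC1` gives 5.21 nM, within the scatter of it. Compound 1 `O=C(Nc1ccc(S(=O)(=O)N2CCCCC2)c2ccccc12)c1ccccc1` reaches only the limit of the assay, > 30000 nM. The change to compound 4 `Cc1ccccc1C(=O)Nc1ccc(S(=O)(=O)NC2CCN(C(=O)N(C)C)CC2)c2ccccc12` is dimethylamino in place of methyl on a carbonyl carbon; cut one bond further out it reads acetyl to dimethylcarbamoyl, 1-acetylpiperidin-4-yl to 1-(dimethylcarbamoyl)piperidin-4-yl, on the amide-type nitrogen in a ring. Within the data shown here, no measured step of this kind exists among the three compounds; compound 2 and compound 3 show only numbers within the scatter of each other. The expected step of a 1.2-fold higher number from compound 3 to compound 4 (0.08 log units; within the scatter) is small, in no direction beyond the scatter. Compound 4 is therefore estimated at 8 nM, between 3 nM and 25 nM.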

Compound 4, inhibition constant: 1.6 nM
The estimate for compound 4 lay 5.0-fold (0.70 log units) above the measured number; the whole stated range lies above it.
By their numbers in this assay, from the lowest: compound 4; then compounds 2 and 3 (each within the scatter of the next). At a limit, above all of these: compound 1.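

Within the data shown here, on the amide-type nitrogen in a ring, the group on the carbonyl carbon affects the number: in this assay dimethylamino in place of methyl gives a 4.2-fold lower number from compound 3 to compound 4 (0.62 log units; beyond the scatter) and is the only one-place step read so far. The three heavy atoms of dimethylamino are accepted where methyl has one, with no hydrogen-bond donors or acceptors counted on either group. Nothing measured here accounts for the step. Still open, on these data alone, is whether diethylamino, a longer chain, or pyrrolidine, a cyclic amine, on the same carbonyl carbon lowers the number further.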